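The source may report more compounds than this note shows. Statements on the series, on what has been measured and on what is new or still open speak of the compounds shown alone.

In a toxicity assay on NIH3T3 cells (Mus musculus) for cytotoxicity, read by resazurin assay (on this read-out lower numbers stand for an effect already at smaller amounts and higher numbers for an effect only at larger amounts of compound), compound 1 `c1ccc(-c2ccc(Cn3cncc3CNc3cccc(-c4ccccc4)c3)cc2)cc1` gives 10000 nM as a plain number. Compound 2 `c1ccc(-c2ccc(Cn3cncc3CNc3ccc(-c4cncs4)c(-c4ccccc4)c3)cc2)cc1` gives > 1000 nM in this assay and this is a limit, not a number. Compound 3 `CC(C)OC(=O)c1ccc(NCc2cncn2Cc2ccc(-c3ccccc3)cc2)cc1-c1ccccc1` differs from compound 2 by isopropoxycarbonyl in place of 1,3-thiazol-5-yl on an aromatic carbon. Among the measured compounds shown here, the only measured step that bears on this change is a step that the limit leaves unreadable from compound 1 to compound 2 and it offers no size to carry over. The one numerical anchor is therefore compound 1 at 10000 nM in the same series, and no direction of change can be argued from the data. The expected move is a step that the limit leaves unreadable from compound 2 to compound 3 in this assay and nothing beyond the scatter is expected. In this assay the expected value for compound 3 is 8000 nM and it is estimated to fall from 2500 nM to 25000 nM on present data.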

Compound 3, half-maximal effective concentration: > 10000 nM
Compound 3: no number, only a limit; the forecaster's own chance of this, stated with the estimate: 35%; at least 1.2-fold (0.09 log units) between middle value and limit.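

Compound 3 gives > 10000 nM in this assay, and this is a limit, not a number. At this position, para to a large group, isopropoxycarbonyl in place of hydrogen gives a number no lower from compound 1 to compound 3 (the limit leaves the size open), so the series now has a direction for a substituent here, which the limit of compound 2 did not give for 1,3-thiazol-5-yl. The steps from compound 1 to compound 2 and from compound 2 to compound 3 cannot be read, so the two groups cannot be ranked against each other.

As far as these compounds go, how far compound 3 lies from compound 1 remains open, since no number exists for compound 3 in this assay. Also open, from the compounds shown here alone, is whether a carboxylic acid or an amine at this same aromatic carbon would give a plain number.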